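Moving the hydroxyl from 4-hydroxyphenyl to 3-hydroxyphenyl

The compounds below may be only part of what the source reports. "The series", "measured", "known", "first", "only" and "open" are said of these compounds alone.

In a functional assay on HepG2 cells (Homo sapiens) for cytotoxicity, read by CCK-8 assay (a higher number here means a weaker inhibitor, a lower number a stronger inhibitor), compound 1 (`COc1ccc(NC(=O)c2ncc(-c3cc(OC)c(OC)c(OC)c3)o2)cc1`) gives > 30000 nM as a limit, not a number. Compound 2 (`O=C(Nc1ccc(O)cc1)c1ncc(-c2ccc(F)cc2)o1`) likewise gives > 30000 nM as a limit. Within the data shown here, compound 3 (`O=C(Nc1ccc(O)cc1)c1ncc(-c2ccccc2)o1`) gives 1270 nM as the only true number so far. Compound 4 (`O=C(Nc1cccc(O)c1)c1ncc(-c2ccccc2)o1`) differs from it by 3-hydroxyphenyl in place of 4-hydroxyphenyl on an amide-type nitrogen with 3-hydroxyphenyl in place of 4-hydroxyphenyl on an amide-type nitrogen. Among the measured compounds shown here, the only measured step, an at least 23-fold lower number from compound 2 to compound 3 (1.37 log units; beyond the scatter), is large but concerns hydrogen in place of fluoro on an aromatic carbon, so it shows only that one change can move this series far. For the measured compounds named here, no measured step touches the hydroxyl. The expected step is a 2.4-fold higher number from compound 3 to compound 4 (0.37 log units; beyond the scatter) in this assay with a moderately higher number as the direction. Compound 4 is estimated at 3000 nM with 900 nM to 15000 nM as the expected range.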

Compound 4, half-maximal inhibitory concentration: > 30000 nM
Compound 4 gave a limit, no number; the forecaster's own chance of this, stated with the estimate: 30%; middle value at least 10-fold (1.00 log units) from the limit.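

The move from 4-hydroxyphenyl to 3-hydroxyphenyl on the amide-type nitrogen gives an at least 23-fold higher number from compound 3 to compound 4 (1.37 log units; beyond the scatter) in this assay, so with the same atoms, joined differently, the place of the hydroxyl alone separates a readable value from none. Single changes on either side of compound 3 now end at the limit. Compound 4 gives a limit, not a number, so the true size of this step stays unread: the limit of > 30000 nM in this assay, at which 3 of the 4 values shown sit.

Open, on these data alone, is what an amine in place of the hydroxyl of 4-hydroxyphenyl would give, with the rest of compound 3 kept.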